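Moving the fluoro group on a series at the limit

The source may report more compounds than this note shows. Statements on the series, on what has been measured and on what is new or still open speak of the compounds shown alone.

Compound 1 `O=C(Nc1ccc2sc(-c3ccccc3F)nc2c1)N1CCCC1`: > 50 uM
Compound 2 `O=C(Nc1ccc2sc(-c3ccccc3)nc2c1)N1CCCCC1`: > 50 uM
Compound 3 `O=C(Nc1ccc2sc(-c3ccccc3F)nc2c1)N1CCCCC1`: > 50 uM

In an ADME assay on HepG2 cells (Homo sapiens) for inhibition, read by resazurin assay, with a stated time of 48 h (on this read-out lower numbers stand for an effect already at smaller amounts and higher numbers for an effect only at larger amounts of compound), compound 1 gives > 50 uM, which is a limit and not a number. The other two entries are limits as well, and the whole set sits at the limit of > 50 uM in this assay, at which 3 of the 3 values shown sit.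

Compound 4 `O=C(Nc1ccc2sc(-c3ccc(F)cc3)nc2c1)N1CCCC1` has 4-fluorophenyl in place of 2-fluorophenyl, on an aromatic carbon of a five-membered aromatic ring with 1 nitrogen and 1 sulfur (4-fluorophenyl in place of 2-fluorophenyl on an aromatic carbon).

Among the measured compounds shown here, no measured step moves the fluoro group. The closest is a step that the two limits leave unreadable from compound 2 to compound 3, with fluoro in place of hydrogen on an aromatic carbon. The other is a step that the two limits leave unreadable from compound 1 to compound 3, with piperidin-1-yl in place of pyrrolidin-1-yl on a carbonyl carbon. Neither has a readable size, so no direction can be drawn from them, and no step beyond the scatter is expected in this assay. The estimated step is a step that the limit leaves unreadable from compound 1 to compound 4. A limit is again the most likely report. For compound 4 the estimate is 70 uM, with an expected range from 35 uM to 150 uM.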

Compound 4, concentration for 90% of the maximal effect: > 50 uM
Compound 4 was reported as a limit; the forecaster's own chance of this, stated with the estimate: 85%; the middle value does not contradict the limit.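

Compound 1 and compound 4 both stand at a limit, so 4-fluorophenyl in place of 2-fluorophenyl gives no step that can be read: the limit of > 50 uM in this assay, at which 4 of the 4 values shown sit.

The compounds shown leave open whether the place of the fluoro group changes anything in this assay, since none of them gives a number there.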